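Methyl in place of chloro on compound 2: expected effect

The source may report more compounds than this note shows. Statements on the series, on what has been measured and on what is new or still open speak of the compounds shown alone.

In a functional assay on HeLa cells (Homo sapiens) for cytotoxicity, read by MTT assay, with a stated time of 24 h (on this read-out lower numbers stand for stronger inhibition and higher numbers for weaker inhibition), compound 1 `C=CC1=C(C(=O)NCc2ccc(Cl)cc2)C(c2ccc(F)cc2)OC1` gives only a limit, > 100000 nM. Compound 2 `C=CC1=C(C(=O)NCc2ccc(Cl)cc2)C(c2ccc(OC)cc2)OC1` likewise gives only a limit, > 100000 nM. Compound 3 `C=CC1=C(C(=O)NCc2ccc(Cl)cc2)C(c2ccc(OC)c(OC)c2)OC1` also gives only a limit, > 100000 nM. Compound 2 thus stands at the limit together with the other two, as shown by the limit of > 100000 nM in this assay, at which 3 of the 3 values shown sit. The steps a step that the two limits leave unreadable from compound 1 to compound 2 and a step that the two limits leave unreadable from compound 2 to compound 3 are both unreadable for that reason. Compound 4 `C=CC1=C(C(=O)NCc2ccc(C)cc2)C(c2ccc(OC)cc2)OC1` differs from compound 2 by methyl in place of chloro on an aromatic carbon. Among the measured compounds shown here, neither measured step involves a change of this kind, and both are unreadable, so no step in this assay can be expected in either direction beyond the scatter. For compound 4 the estimated step is a step that the limit leaves unreadable from compound 2 to compound 4. Compound 4 is expected to give 150000 nM, between 60000 nM and 400000 nM, most likely reported again only as a limit.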

Compound 4, half-maximal inhibitory concentration: 15900 nM
For compound 4 the middle estimate is 9.4-fold (0.97 log units) above the measured one; measured number outside the range, below it.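

In this assay, among the compounds shown here, the change from 4-chlorobenzyl to 4-methylbenzyl gives an at least 6.2-fold lower number from compound 2 to compound 4 (0.79 log units; beyond the scatter), whereas the steps among the earlier compounds, all made on the other aromatic ring, cannot be read. This position therefore responds to a swap of one heavy atom, and it gives the only measured number in the set: the limit of > 100000 nM in this assay, at which 3 of the 4 values shown sit.

Going by these compounds, the true size of the step stays open, since compound 2 gives only a limit. The compounds shown also leave open how an ethyl group or an amine would behave at this position, and whether methyl in place of chloro has the same effect on compound 1 or compound 3.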